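Series notes: aryl sulfonamides at the serotonin receptor

This account rests on a few compounds, and the source may have more. Where it says the series, first, only, none or still open, it means among the compounds named here.

Measured compounds in an assay on isolated protein for displacement of a labelled ligand from 5-hydroxytryptamine receptor 6 (Homo sapiens), read by radioligand binding; a higher number here means a weaker inhibitor, a lower number a stronger inhibitor:
- compound 1, `CN1CCc2cc(Cl)c(NS(=O)(=O)c3ccc(-c4ccc(Cl)cc4)cc3)cc2CC1`, 50.1 nM
- compound 2, `CCCCc1ccc(S(=O)(=O)Nc2ccc3c(c2)CCNCC3)cc1`, 2 nM
- compound 3, `CN1CCc2ccc(NS(=O)(=O)c3ccc(-c4ccc(F)c(Cl)c4)cc3)cc2CC1`, 7.94 nM

Compound 3 gives 7.94 nM in this assay and stands second highest of the three numbers. Its nearest neighbour is compound 2 with 2 nM, a lower number, and the gap between them lies beyond the scatter. The furthest is compound 1 with 50.1 nM, a higher number, again beyond the scatter. For the measured compounds named here, no pair among the three differs in a single place, so no single-point step is available from the measured set.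

Compound 4, `Cc1noc(C)c1-c1ccc(S(=O)(=O)Nc2ccc3c(c2)CCN(C)CC3)cc1`, is the next compound in this assay. It differs from compound 3 in one place: 3,5-dimethyl-1,2-oxazol-4-yl in place of 3-chloro-4-fluorophenyl on an aromatic carbon. A 3,5-dimethyl-1,2-oxazol-4-yl thus replaces a 3-chloro-4-fluorophenyl para to a large group.

Going by the values given here, with no comparable step among the measured compounds, the expectation rests on the measured spread alone, which runs from compound 2 to compound 1. A moderate rise in the number is expected for compound 4, that is a step from compound 3 of a 3.1-fold higher number from compound 3 to compound 4 (0.50 log units; beyond the scatter), direction toward a weaker inhibitor, likely beyond the scatter but not certainly so. Compound 4 is estimated at 25 nM, with a range from 6 nM to 100 nM.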

Compound 4, inhibition constant: 10 nM
Beside the measured number, compound 4's estimate is 2.5-fold (0.40 log units) above it; measured number inside the range.
By their numbers in this assay, from the lowest: compound 2; then compounds 3 and 4 (each within the scatter of the next); then compound 1.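

In this assay, the step of a 1.3-fold higher number from compound 3 to compound 4 (0.10 log units; within the scatter) gives the series its first single-place comparison, and it lies within the scatter. On this aromatic carbon, para to a large group, the assay therefore does not separate 3,5-dimethyl-1,2-oxazol-4-yl from 3-chloro-4-fluorophenyl, even though the entering group brings a five-membered aromatic ring with 2 hetero atoms and 2 hydrogen-bond acceptors, while the leaving group has a six-membered aromatic ring of carbon only, 0 hydrogen-bond acceptors, and both a fluorine and a chlorine. Nothing measured here bears on why these two groups read alike.

The compounds shown leave open whether this match extends beyond these two aromatic rings to a group such as a primary amine, a carboxylic acid or a morpholine at the same place. From the compounds shown here alone, it also remains open whether the same exchange would read the same way on a core carrying a chlorine, as the core of compound 1 does.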